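Removing a methoxy from a bis-aryl fused core

A few compounds are considered here, and "the series" means these few. Any claim that something is new, unique, unknown or untested is made for them only; others in the source may bear on it.

Measured compounds:
compound 1, `c1ccc(-c2nc3sc(-c4ccccc4)cn3n2)cc1`: 13%
compound 2, `COc1ccc(-c2nc3sc(-c4ccc(Cl)cc4)cn3n2)cc1`: -25.8%

In a functional assay on A498 cells (Homo sapiens) for inhibition, read by sulforhodamine B assay, with a stated time of 48 h, tested at 10 uM (on this read-out lower numbers stand for less inhibition of growth and higher numbers for more inhibition of growth at the one concentration tested), compound 1 gives 13%. Compound 2 stands lowest of the two numbers, with -25.8%; its nearest neighbour is compound 1, whose value lies higher by a gap that is beyond the usual scatter. Compound 3, `Clc1ccc(-c2cn3nc(-c4ccccc4)nc3s2)cc1`, has not yet been measured in this assay. Compared with compound 2 it shows one change: hydrogen in place of methoxy on an aromatic carbon. Going by the values given here, no step between measured compounds covers this change. Compound 3 shares its unsubstituted phenyl with compound 1 and its chlorophenyl with compound 2, so an upward step of moderate size is expected from compound 2 to compound 3, namely a number 20.8 percentage points higher from compound 2 to compound 3 (beyond the scatter), probably just beyond the scatter. For compound 3 the estimated value in this assay is -5%, with a range from -28% to 18%.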

Compound 3, percent growth inhibition at one concentration: 52%
Estimate against measurement, compound 3: 57 percentage points below, outside the stated range (above it).
By their numbers in this assay, from the lowest: compound 2; then compound 1; then compound 3.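

In this assay, the place on the aromatic carbon para to a large group turns out to matter greatly, since hydrogen in place of methoxy gives a large step (a number 77.8 percentage points higher from compound 2 to compound 3 (beyond the scatter)), so the low value of compound 2 goes with the methoxy and not with the chlorophenyl it shares with compound 3. Chloro in place of hydrogen on an aromatic carbon, with the other phenyl unsubstituted, also gives a large upward step (a number 39 percentage points higher from compound 1 to compound 3 (beyond the scatter)), showing that the chloro goes with more inhibition of growth once the methoxy is gone. No measurement at hand gives a reason for either step.

From the compounds shown here alone, whether a hydroxyl or an amine at the methoxy's place would read closer to compound 2 or to compound 3 remains open. So does whether a fluoro or a carboxylic acid could stand in for the chloro.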